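Swapping a carbamate for an ethyl on a ring nitrogen

The source may report more compounds than this note shows. Statements on the series, on what has been measured and on what is new or still open speak of the compounds shown alone.

Of the compounds shown here, three have been tested in a toxicity assay on HeLa cells (Homo sapiens) for cytotoxicity, read by MTT assay, with a stated time of 24 h; on this read-out higher numbers stand for weaker inhibition and lower numbers for stronger inhibition. Compound 1 `Cc1ncc([N+](=O)[O-])n1CC(O)CSC(=S)N1CCN(c2cccc(Cl)c2)CC1` gives 1080000 nM in this assay. Compound 2 `Cc1ncc([N+](=O)[O-])n1CC(O)CSC(=S)N(C)C` reaches only the limit of this assay, at > 5000000 nM, which is a boundary rather than a number. Compound 3 `CCOC(=O)N1CCN(CC(O)Cn2c([N+](=O)[O-])cnc2C)CC1` gives 3670000 nM in this assay, the highest of the two numbers recorded, and its nearest neighbour, compound 1, sits lower by a gap that is beyond the usual scatter. All three compounds thus show weak cytotoxicity in this assay.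

Compound 4 `CCN1CCN(CC(O)Cn2c([N+](=O)[O-])cnc2C)CC1` has not yet been measured. It differs from compound 3 in one place: ethyl in place of ethoxycarbonyl on an amine nitrogen in a ring. Among the compounds with values here, no step between two measured compounds of this kind is available to guide the expectation, so only the spread of the three known results can be used. The change is expected to move the value little, with a step of a 1.2-fold lower number from compound 3 to compound 4 (0.09 log units; within the scatter) that is probably within the scatter. Compound 4 is therefore estimated to give about 3000000 nM in this assay, in a range from 1000000 nM to 9000000 nM.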

Compound 4, half-maximal inhibitory concentration: 4940000 nM
Compound 4: the middle estimate sits 1.6-fold (0.22 log units) below what was measured; low and high end bracket the measured number.
By their numbers in this assay, from the lowest: compound 1; then compounds 3 and 4 (each within the scatter of the next). At a limit, above all of these: compound 2.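

Ethyl takes the place of the larger ethoxycarbonyl on this amine nitrogen in the ring, removing its hydrogen-bond acceptors, and in this assay the outcome is a 1.3-fold higher number from compound 3 to compound 4 (0.13 log units; within the scatter). This first step between two measured compounds therefore shows that, for this pair, losing the carbonyl makes no difference that can be told from the scatter, and both compounds remain only weakly cytotoxic. Little room may remain for reading any further weakening, as compound 2 stands at a limit of the assay rather than at a number: the limit of > 5000000 nM in this assay, at which 1 of the 4 values shown sits.

As far as these compounds go, whether any group on this nitrogen can lower the number appreciably remains open. A longer alkyl chain, a benzyl group or a carboxylic acid at this place would test that, and the two groups shown cannot predict their effect.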